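This account rests on a few compounds, and the source may have more. Where it says the series, first, only, none or still open, it means among the compounds named here.

Measured in a functional assay on HL-60 cells (Homo sapiens) for antiproliferative activity, read by MTT assay, with a stated time of 72 h; on this read-out higher numbers stand for weaker inhibition and lower numbers for stronger inhibition:
- compound 1 `COc1cc(-c2ncnn2-c2ccc([N+](=O)[O-])cc2)cc(OC)c1OC`: > 10000 nM
- compound 2 `COc1cc(-n2ncnc2-c2ccc(OC(F)(F)F)cc2)cc(OC)c1OC`: > 10000 nM
- compound 3 `COc1cc(-n2ncnc2-c2cccc([N+](=O)[O-])c2)cc(OC)c1OC`: > 10000 nM

Each of these entries is a limit of the assay and not a number. In this assay compound 2 gives > 10000 nM, which is a limit. It has no better or worse place in the series, which so far shows only (the limit of > 10000 nM in this assay, at which 3 of the 3 values shown sit).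

Next is compound 4 `COc1cc(-n2ncnc2-c2ccc(SC)cc2)cc(OC)c1OC`, which carries methylsulfanyl in place of trifluoromethoxy on an aromatic carbon, para to a large group: methylsulfanyl in place of trifluoromethoxy on an aromatic carbon. For the measured compounds named here, no measured pair gives a step to lean on, so the size of this one remains uncertain. A modest move toward stronger inhibition is expected, though staying at the limit is about as likely, given (the limit of > 10000 nM in this assay, at which 3 of the 3 values shown sit). The expected change is an at least 1.6-fold lower number from compound 2 to compound 4 (0.22 log units; that floor lies within the scatter). The estimate for compound 4 is 6000 nM, with an expected range of 500 nM to 10000 nM.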

Compound 4, half-maximal inhibitory concentration: 500 nM
Estimate against measurement, compound 4: 12-fold (1.08 log units) above; the range from low to high includes it.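

In this assay, for the compounds shown here, methylsulfanyl in place of trifluoromethoxy on an aromatic carbon, para to a large group, gives the only number so far, with an at least 20-fold lower number from compound 2 to compound 4 (1.30 log units; beyond the scatter). On the shared core, this position can therefore separate a compound at the limit from a measurable one, through the exchange of this single group. The step is only a floor, since one end of it is a limit and not a number: the limit of > 10000 nM in this assay, at which 3 of the 4 values shown sit.

Going by these compounds, it remains open whether the sulfur atom itself matters, as a methoxy group at this position would test, or whether a longer chain such as ethylsulfanyl keeps the value of compound 4. Compound 1 and compound 3 differ from compound 4 in more than one place, so they cannot be read against this step.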